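Halogenated benzophenones: cyclic amine and aryl halide swaps

The source may report more compounds than this note shows. Statements on the series, on what has been measured and on what is new or still open speak of the compounds shown alone.

Measured compounds:
compound 1, `COc1cc(OC)c(C(=O)c2cccc(Cl)c2)c(O)c1CN1CCCCC1`, in a functional assay on THP-1 cells (Homo sapiens) for inhibition, read by ELISA, with stated times of 30 min and 24 h, tested at 1 uM (on this read-out higher numbers stand for a stronger effect at the one concentration tested and lower numbers for a weaker effect), gives 33%
compound 2, `COc1cc(OC)c(C(=O)c2ccccc2Br)c(O)c1CN1CCCCC1`, gives 22% in this assay
compound 3, `COc1cc(OC)c(C(=O)c2cccc(Cl)c2)c(O)c1CN1CCCC1`, gives 41% in this assay

Two changes run through the set. The first is 2-bromophenyl in place of 3-chlorophenyl on a carbonyl carbon, which gives a number 11 percentage points lower from compound 1 to compound 2 (beyond the scatter). The second, which separates the core of compound 1 from the core of compound 3, is pyrrolidin-1-yl in place of piperidin-1-yl on a saturated chain carbon bound to an aromatic carbon, and it gives a number 8 percentage points higher from compound 1 to compound 3 (within the scatter). Compound 4, `COc1cc(OC)c(C(=O)c2ccccc2Br)c(O)c1CN1CCCC1`, is not yet measured; it differs from compound 3 by 2-bromophenyl in place of 3-chlorophenyl on a carbonyl carbon, the same change as from compound 1 to compound 2, at the same place. For the measured compounds named here, the step expected for compound 4 is a number 11 percentage points lower from compound 3 to compound 4 (beyond the scatter), set beside the earlier one because a number 11 percentage points lower from compound 1 to compound 2 (beyond the scatter) is the only measure of this change in the set. Compound 4 is therefore estimated at 30%, expected between 18% and 42%.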

Compound 4, a percentage reported as activity, at one concentration (the size of the read-out at that concentration, not a potency): 19%
Estimate against measurement, compound 4: 11 percentage points above; measured number inside the range.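

In this assay, 2-bromophenyl in place of 3-chlorophenyl gives a number 22 percentage points lower from compound 3 to compound 4 (beyond the scatter) on the pyrrolidin-1-yl core, the same direction as on the piperidin-1-yl core, and the two readings do not separate: the same change on two cores in this assay, a number 11 percentage points lower (beyond the scatter) from compound 1 to compound 2 and a number 22 percentage points lower (beyond the scatter) from compound 3 to compound 4, 11 percentage points apart, within the scatter of two such steps. The reverse view of the amine swap gives a number 3 percentage points lower from compound 2 to compound 4 (within the scatter) and stays within the scatter on both cores: the same change on two cores in this assay, a number 8 percentage points higher (within the scatter) from compound 1 to compound 3 and a number 3 percentage points lower (within the scatter) from compound 2 to compound 4, 11 percentage points apart, within the scatter of two such steps. Two cores at a single concentration support carrying the direction of the aryl change across this pair, but they fix neither its size on a further core nor any potency.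

The compounds shown leave open whether the drop follows the halogen or its place on the ring, which 3-bromophenyl and 2-chlorophenyl on the carbonyl carbon would separate. They also leave open how morpholine on the saturated chain carbon would read.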